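The source may hold more compounds than are shown below. What is called first, only, known or untested is meant among the compounds shown, and "the series" means these compounds.

Of the compounds shown here, three sharing one core have been measured in a functional assay on MDA-MB-231 cells (Homo sapiens) for inhibition, read by MTT assay, with a stated time of 72 h; on this read-out higher numbers stand for weaker inhibition and lower numbers for stronger inhibition. Compound 1 `O=C(CSc1nc(Nc2ccccc2)c2ccccc2n1)Nc1cccc(F)c1` sits at a limit of this assay, giving > 50000 nM. Compound 2 `O=C(CSc1nc(Nc2ccccc2)c2ccccc2n1)Nc1ccc(Cl)cc1Cl` gives 19400 nM in this assay, and compound 3 `C=CC(=O)Nc1cccc(NC(=O)CSc2nc(Nc3ccccc3Cl)c3ccccc3n2)c1` gives 12700 nM. Compound 3 shows the lowest of the two numbers, but its nearest neighbour is compound 2 and that gap is within the scatter, so the two cannot be ordered. Among the measured compounds shown here, the one step known between measured compounds, an at least 2.5-fold lower number from compound 1 to compound 2 (0.41 log units; beyond the scatter), concerns an exchange of halogenated phenyl groups on an amide-type nitrogen, and its size rests in part on (the limit of > 50000 nM in this assay, at which 1 of the 3 values shown sits).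

Compound 4 `C=CC(=O)Nc1cccc(NC(=O)CSc2nc(Nc3ccc(F)c(Cl)c3)c3ccccc3n2)c1` differs from compound 3 in one place: 3-chloro-4-fluorophenyl in place of 2-chlorophenyl on a nitrogen on an aromatic ring. The 2-chlorophenyl leaves and 3-chloro-4-fluorophenyl enters, on a nitrogen on an aromatic ring whose other neighbours are aromatic carbon. For the measured compounds named here, no measured step touches that nitrogen; the step from compound 1 to compound 2 lies on the amide-type nitrogen instead and so bears only indirectly. It shows that rearranging halogens on a phenyl can move this assay by a modest amount, yet nothing more specific. The expectation is therefore a step of a 1.3-fold lower number from compound 3 to compound 4 (0.10 log units; within the scatter), not beyond the scatter. Compound 4 is estimated at 10000 nM in this assay, within a range from 4000 nM to 30000 nM.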

Compound 4, half-maximal inhibitory concentration: 10600 nM
For compound 4 the middle estimate is 1.1-fold (0.03 log units) below the measured one; measured number inside the range.
By their numbers in this assay, from the lowest: compounds 4, 3 and 2 (each within the scatter of the next). At a limit, above all of these: compound 1.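

Among the compounds shown here, the step at this nitrogen is the first to be read directly: in this assay the exchange gives a 1.2-fold lower number from compound 3 to compound 4 (0.08 log units; within the scatter), so compound 3 and compound 4 cannot be ordered. Taken alone, this pair shows that a 2-chlorophenyl and a 3-chloro-4-fluorophenyl on a nitrogen on an aromatic ring are not told apart by this read-out, even though the two groups differ in the number and the placing of their halogens. That contrasts with the step on the amide-type nitrogen, which was beyond the scatter, but one exchange at each place gives no general rule, and nothing on record accounts for the absence of a readable change at this nitrogen.

The compounds shown leave open whether a group of another kind on this nitrogen, such as a phenyl carrying a carboxylic acid or an aliphatic amine in place of the halogens, would move the number beyond the scatter. For the compounds shown here, they also hold no pair that differs only on the amide-type nitrogen while carrying either of these two halogenated phenyl groups, so the contribution of that side to compound 3 and compound 4 remains unresolved.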